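The source may hold more compounds than are shown below. What is called first, only, known or untested is meant among the compounds shown, and "the series" means these compounds.

Measured so far:
- compound 1 `O=C(Cn1cc(-c2ccc([N+](=O)[O-])cc2)nn1)Nc1nccs1`: 1040 nM
- compound 2 `O=C(Cn1cc(-c2cccc(Cl)c2)nn1)Nc1nccs1`: > 30000 nM

The shared core of compound 1 and compound 2 carries a phenyl group, and only the substitution of this group differs between them. In a functional assay on BMDM cells (Mus musculus, strain C57BL/6) for inhibition, with a stated time of 2 days (a higher number here means a weaker inhibitor, a lower number a stronger inhibitor), compound 1 gives 1040 nM. For compound 2 this assay reports only a limit, > 30000 nM, so no number is known for it. Compound 2 thus stands at the limit of > 30000 nM in this assay, at which 1 of the 2 values shown sits, the weaker end of what has been measured. Compound 3 `O=C(Cn1cc(-c2ccc(Cl)cc2)nn1)Nc1nccs1` takes the next step from compound 2: 4-chlorophenyl in place of 3-chlorophenyl on an aromatic carbon. Since compound 2 is known only as a limit, this step cannot be set against a measured one. Compound 3 differs from compound 1 only in the group on that carbon, and the value of compound 1 1040 nM shows that a measurable number is reachable there. The step from compound 2 to compound 3 is expected to be an at least 6.0-fold lower number from compound 2 to compound 3 (0.77 log units; beyond the scatter), toward stronger inhibition and beyond the scatter. Compound 3 is therefore estimated at 5000 nM, between 1000 nM and 30000 nM.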

Compound 3, half-maximal inhibitory concentration: 1100 nM
The estimate for compound 3 lay 4.5-fold (0.66 log units) above the measured number; low and high end bracket the measured number.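

Moving the chlorine around the phenyl group, with the atoms otherwise unchanged, is enough to matter in this assay: 4-chlorophenyl in place of 3-chlorophenyl gives an at least 27-fold lower number from compound 2 to compound 3 (1.43 log units; beyond the scatter). Compound 2 is known only as a limit: the limit of > 30000 nM in this assay, at which 1 of the 3 values shown sits.

Chloro in place of nitro on an aromatic carbon gives a 1.1-fold higher number from compound 1 to compound 3 (0.02 log units; within the scatter), so this swap stays within the scatter while the move of the chlorine does not.

As far as these compounds go, it remains open whether other groups on the phenyl ring, such as an amine, a carboxylic acid or a methoxy group, would read like chloro and nitro, and whether 3-nitrophenyl would also end at a limit. The compounds shown also cannot tell why the place of the chlorine matters so much.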